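Three Compounds at the Assay Limit, a Fourth Expected There

A few compounds are considered here, and "the series" means these few. Any claim that something is new, unique, unknown or untested is made for them only; others in the source may bear on it.

The set consists of compound 1 `Oc1ccccc1-c1cc(-c2ccc(C(F)(F)F)cc2)cc(-c2ccccc2O)n1`, compound 2 `Oc1cccc(-c2cc(-c3ccc(C(F)(F)F)cc3)cc(-c3ccccc3O)n2)c1`, compound 3 `Oc1ccccc1-c1cc(-c2cccc(OC(F)(F)F)c2)cc(-c2ccccc2O)n1` and compound 4 `Oc1cccc(-c2cc(-c3cccc(OC(F)(F)F)c3)cc(-c3ccccc3O)n2)c1`, which has not yet been tested. The read-out is a functional assay on HCT-15 cells (Homo sapiens) for inhibition; on this read-out lower numbers stand for stronger inhibition and higher numbers for weaker inhibition.

In this assay compound 1 reaches only a limit of the assay, > 50000 nM. Compound 2 likewise gives only a limit, > 50000 nM. Compound 3 also returns only a limit, > 50000 nM. Taken together, (the limit of > 50000 nM in this assay, at which 3 of the 3 values shown sit).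

Compound 2 differs from compound 1 by 3-hydroxyphenyl in place of 2-hydroxyphenyl on an aromatic carbon. The resulting step, a step that the two limits leave unreadable from compound 1 to compound 2, cannot be sized from these two values. The difference between the core of compound 1 and the core of compound 3 is not broken down here. Compound 4 differs from compound 3 by 3-hydroxyphenyl in place of 2-hydroxyphenyl on an aromatic carbon. This is the same kind of change as that from compound 1 to compound 2, though the surroundings differ: in compound 1 the place is meta to a 4-(trifluoromethyl)phenyl group, whereas in compound 3 it is meta to a large group.

Because compound 3 sits at > 50000 nM, and because the same kind of change from compound 1 to compound 2 left both compounds at the limit of > 50000 nM in this assay, at which 3 of the 3 values shown sit, compound 4 is expected to remain at the limit as well, with an estimated step that the limit leaves unreadable from compound 3 to compound 4. For compound 4 the estimated value in this assay is 100000 nM, expected to lie between 40000 nM and 300000 nM.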

Compound 4, half-maximal inhibitory concentration: 2740 nM
For compound 4 the middle estimate is 36-fold (1.56 log units) above the measured one; measured number below the stated range.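

In this assay, putting 3-hydroxyphenyl in place of 2-hydroxyphenyl on the core of compound 3 gives an at least 18-fold lower number from compound 3 to compound 4 (1.26 log units; beyond the scatter), a large change beyond the usual scatter, and compound 4 stands at 2740 nM as a real number rather than a limit. For the compounds shown here, on the core of compound 1 the same change yields compound 2, which gives only a limit of the assay, > 50000 nM, and the step there cannot be read, so the two cores offer no pair of readable steps to set side by side. The change is therefore shown to strengthen inhibition on one core only; the series neither shows that it carries over to the core of compound 1 nor that it fails there, and the values left for comparison are mostly limits: the limit of > 50000 nM in this assay, at which 3 of the 4 values shown sit.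

The compounds shown leave open whether the effect seen in compound 4 would hold if the hydroxyl group of the 3-hydroxyphenyl ring gave way to an amine or a carboxylic acid. They also leave open what happens when the remaining 2-hydroxyphenyl group of compound 4 undergoes the same change, and what lies behind the step itself.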